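The source may report more compounds than this note shows. Statements on the series, on what has been measured and on what is new or still open speak of the compounds shown alone.

Measured so far in an ADME assay on BHK-21 cells (Mesocricetus auratus) for cytotoxicity, read by MTT assay (a lower number here means that less compound is tolerated, a higher number that more compound is tolerated), as follows
compound 1 `C/C(=N\NC(N)=S)c1ccc2[nH]c(-c3ccc(Cl)cc3)nc2c1` gives > 100000 nM as a limit
compound 2 `C/C(=N\NC(N)=O)c1ccc2[nH]c(C3CCCCC3)nc2c1` gives > 100000 nM as a limit

For the measured compounds named here, compound 2 sits at a limit and not at a number, with > 100000 nM as its only reading. Going by the values given here, the series so far shows the limit of > 100000 nM in this assay, at which 2 of the 2 values shown sit, and no measured number. The change to compound 3 `C/C(=N\NC(N)=S)c1ccc2[nH]c(C3CCCCC3)nc2c1` takes the carbamoyl off an amine nitrogen and puts a group with sulfur in its place, a group of 3 heavy atoms (1 carbon, 1 nitrogen, 1 sulfur; no ring) in place of a group of 3 heavy atoms (1 carbon, 1 nitrogen, 1 oxygen; no ring), on an amine nitrogen and the rest of compound 2 stays the same. Among the compounds with values here, no measured step covers this swap in this assay and its size has to be expected from limits alone. Compound 1, which already carries the entering group on a different core, is a limit at > 100000 nM and gives no sign of a large fall. Expected is a small downward step an at least 1.2-fold lower number from compound 2 to compound 3 (0.09 log units; that floor lies within the scatter) that stays within the usual scatter. Compound 3 is estimated at 80000 nM with an expected range from 30000 nM to 150000 nM in this assay and may well read as a limit again.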

Compound 3, half-maximal cytotoxic concentration: 24000 nM
The estimate for compound 3 lay 3.3-fold (0.52 log units) above the measured number; measured number below the stated range.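

In this assay, the sulfur-bearing group in place of the carbamoyl on the amine nitrogen gives an at least 4.1-fold lower number from compound 2 to compound 3 (0.61 log units; beyond the scatter), so this swap can move the tolerated concentration beyond the scatter when cyclohexyl is present. With the sulfur-bearing group held, cyclohexyl in place of 4-chlorophenyl on an aromatic carbon gives an at least 4.1-fold lower number from compound 1 to compound 3 (0.61 log units; beyond the scatter), so the group at that place also matters in this assay. Compound 3 now provides the only measured number in the series, and the other readings remain limits: the limit of > 100000 nM in this assay, at which 2 of the 3 values shown sit.

From the compounds shown here alone, both steps are floors, and their full size stays open. Also open, going by these compounds, is where a phenyl without chlorine or an n-butyl chain on the aromatic carbon would read alongside the sulfur-bearing group.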